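The source may report more compounds than this note shows. Statements on the series, on what has been measured and on what is new or still open speak of the compounds shown alone.

Compound 1 `Cc1n[nH]c(C(=O)O)c1Cc1cccc(-c2ccc(C#N)cc2)c1` gives 300 nM in an assay on isolated protein for inhibition of 2-Hydroxyacid oxidase 2 (Rattus norvegicus); on this read-out lower numbers stand for stronger inhibition and higher numbers for weaker inhibition. Compound 2 `Cc1n[nH]c(C(=O)O)c1Cc1cccc(-c2ccc(C(N)=O)cc2)c1` gives 200 nM.

Compound 2 has the lowest of the two numbers, but the step of a 1.5-fold lower number from compound 1 to compound 2 (0.18 log units; within the scatter) lies within the scatter, so the two compounds cannot be told apart. Compound 3 `Cc1n[nH]c(C(=O)O)c1Cc1cccc(-c2ccc(C(=O)O)cc2)c1` differs from compound 2 by hydroxy in place of amino on a carbonyl carbon. For the measured compounds named here, the one measured step concerns cyano against carbamoyl, a different exchange, so nothing measured tests this change directly. Compound 3 is therefore expected to move by a 1.5-fold higher number from compound 2 to compound 3 (0.18 log units; within the scatter) from compound 2, a step not beyond the scatter, with wide uncertainty. The estimate for compound 3 is 300 nM, between 100 nM and 900 nM.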

Compound 3, half-maximal inhibitory concentration: 1100 nM
The estimate for compound 3 lay 3.7-fold (0.56 log units) below the measured number; the whole stated range lies below it.
By their numbers in this assay, from the lowest: compounds 2 and 1 (each within the scatter of the next); then compound 3.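

The group on this aromatic carbon does affect the read-out in this assay: replacing carbamoyl with carboxy gives a 5.5-fold higher number from compound 2 to compound 3 (0.74 log units; beyond the scatter), and replacing cyano with carboxy gives a 3.7-fold higher number from compound 1 to compound 3 (0.56 log units; beyond the scatter). For the compounds shown here, the earlier pair could not be told apart, so carboxy is the first group here to separate itself from the others, with the higher number. Nothing available explains this difference.

Still open, as far as these compounds go, is how other groups in this place would compare, such as a methyl ester, a sulfonamide or an aminomethyl group.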